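A few compounds are considered here, and "the series" means these few. Any claim that something is new, unique, unknown or untested is made for them only; others in the source may bear on it.

In a functional assay on ileum (Cavia porcellus) with cysteinyl leukotriene receptor (Homo sapiens) as the target (on this read-out lower numbers stand for lower potency and higher numbers for higher potency (the scale is a negative logarithm)), compound 2 `CCCc1c(COc2ccc(C(=O)CCCC(=O)O)cc2)ccc(C(C)=O)c1O` gives 6.81, which is the higher of the two single numbers shown, with compound 1 `CCCc1c(COc2ccc(C(=O)CCC(=O)O)cc2)ccc(C(C)=O)c1O` close behind at 6.75; compound 3 `CCc1c(COc2ccc(C(=O)CC(C)(C)CC(=O)O)cc2)ccc(C(C)=O)c1O` gives 7.46; 7.6 (2 entries), being recorded more than once, as the several entries of compound 3 in this assay, 7.46; 7.6 (2 entries). The step to compound 4 `CCCc1c(COc2ccc(C(=O)CCCCCCc3nnn[nH]3)cc2)ccc(C(C)=O)c1O` replaces the carboxy group with a 3-(1H-tetrazol-5-yl)propyl group (3-(1H-tetrazol-5-yl)propyl in place of carboxy on a saturated chain carbon, three bonds along the chain from a carbonyl carbon). Among the measured compounds shown here, the only measured step that touches this chain end is a number 0.06 log units higher from compound 1 to compound 2 (within the scatter), a shift within the scatter, so lengthening the chain by itself gives no reason to expect a large move; nothing measured speaks to the tetrazole in place of the acid. Compound 4 is therefore expected to stay near compound 2 in this assay, with a step of a number 0.19 log units higher from compound 2 to compound 4 (within the scatter) and a wide range. The estimate for compound 4 is 7, between 6.3 and 7.7.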

Compound 4, negative logarithm of the antagonist equilibrium constant: 7.33
Compound 4: the middle estimate sits 0.33 log units below what was measured; measured number inside the range.
By their numbers in this assay, from the lowest: compounds 1 and 2 (each within the scatter of the next); then compound 4.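

Until now, changes at this chain end had stayed within the scatter. Replacing carboxy with 3-(1H-tetrazol-5-yl)propyl gives the first clear move, a number 0.52 log units higher from compound 2 to compound 4 (beyond the scatter), and likewise a number 0.58 log units higher from compound 1 to compound 4 (beyond the scatter), so this chain end accepts a much larger group ending in a five-membered aromatic ring without any loss. Nothing at hand accounts for this gain.

Compound 4 changes chain length and end group together, leaving their shares of the step apart. A carboxylic acid on the same longer chain, or 1H-tetrazol-5-yl on a shorter one, would separate them.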